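This account rests on a few compounds, and the source may have more. Where it says the series, first, only, none or still open, it means among the compounds named here.

Compound 1, `FC(F)(F)c1ccc(CN2CCN(Cc3cc(-c4ccc(OCc5ccccc5)cc4)on3)CC2)cc1`, gives 2900 nM in a functional assay on MCF7 cells (Homo sapiens) for antiproliferative activity, read by sulforhodamine B assay, with a stated time of 72 h; a lower number here means a stronger inhibitor, a higher number a weaker inhibitor.
Compound 2, `FC(F)(F)c1ccc(CN2CCN(Cc3cc(-c4ccc(OCc5ccc(Cl)cc5)cc4)on3)CC2)cc1`, gives 6700 nM in this assay.
Compound 3, `N#Cc1cccc(COc2ccc(-c3cc(CN4CCN(c5ccc(C(F)(F)F)cc5)CC4)no3)cc2)c1`, gives 2000 nM in this assay.

Compound 3 has the lowest of the three numbers, but its gap to compound 1 is within the scatter, while its gap to compound 2 is beyond it. For the measured compounds named here, the only step between measured neighbours is a 2.3-fold higher number from compound 1 to compound 2 (0.36 log units; beyond the scatter), which concerns the far end of the shared core and not the amine nitrogen in a ring.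

Compound 4, `N#Cc1cccc(COc2ccc(-c3cc(CN4CCN(C(=O)C5CC5)CC4)no3)cc2)c1`, differs from compound 3 in one place: cyclopropylcarbonyl in place of 4-(trifluoromethyl)phenyl on an amine nitrogen in a ring. Going by the values given here, no measured pair shows a change at this nitrogen, so nothing in the data sets the size or direction of this step. With the change so far from what has been tested, the account leans toward a weaker number with wide uncertainty. Compound 4 is therefore expected to give 4500 nM in this assay, with a range from 1500 nM to 15000 nM. That estimate means a step of a 2.3-fold higher number from compound 3 to compound 4 (0.35 log units; beyond the scatter), which is no more than a guess beyond the scatter.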

Compound 4, half-maximal inhibitory concentration: 7600 nM
Compound 4: middle estimate off by 1.7-fold (0.23 log units), on the low side; measured number inside the range.
By their numbers in this assay, from the lowest: compounds 3 and 1 (each within the scatter of the next); then compounds 2 and 4 (each within the scatter of the next).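

For the compounds shown here, the result gives the first measured change at the amine nitrogen in the ring, and the position proves sensitive to what it carries: in this assay, cyclopropylcarbonyl in place of 4-(trifluoromethyl)phenyl gives a 3.8-fold higher number from compound 3 to compound 4 (0.58 log units; beyond the scatter). The swap removes a six-membered aromatic ring and brings in both a three-membered ring and a hydrogen-bond acceptor, so this single step cannot assign the higher number to any one of these differences. Nothing measured here explains the step.

Going by these compounds, it remains open whether the loss of the aromatic ring or the arrival of the carbonyl sets the size of this step, a question that cyclopropylmethyl or plain phenyl on the same nitrogen of compound 3 would address. On these data alone, whether a step of this size would recur with another group at the far end of the shared core also stays unknown.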